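The compounds below may be only part of what the source reports. "The series", "measured", "known", "first", "only" and "open" are said of these compounds alone.

Compound 3 `CN(C)CCNc1ccnc2cc(OCc3ccccc3)ccc12` is one of three compounds tested in a functional assay on HepG2 cells (Homo sapiens) for cytotoxicity, read by MTT assay, with a stated time of 48 h (on this read-out lower numbers stand for stronger inhibition and higher numbers for weaker inhibition), the others being compound 1 `CC(C)COc1ccc2c(Cl)ccnc2c1` and compound 2 `CCCCOc1ccc2c(Cl)ccnc2c1`. In this assay compound 1 gives 2250 nM, compound 2 gives 2640 nM, and compound 3 gives 3120 nM. Compound 3 has the highest of the three numbers, but its gap to compound 2 and to compound 1 is within the scatter, so the three cannot be ordered. Going by the values given here, the only step among measured pairs, a 1.2-fold higher number from compound 1 to compound 2 (0.07 log units; within the scatter), changes the alkoxy chain and does not concern the group exchanged here.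

Compound 4 `Clc1ccnc2cc(OCc3ccccc3)ccc12` differs from compound 3 by chloro in place of (2-(dimethylamino)ethyl)amino on an aromatic carbon. Among the compounds with values here, no measured step covers this exchange. Compound 1 and compound 2, however, already carry chloro at that place with a different ether, and their values sit within the scatter of compound 3. The step of a 1.2-fold lower number from compound 3 to compound 4 (0.08 log units; within the scatter) is therefore expected to stay within the scatter. For compound 4 the estimate in this assay is 2600 nM, with a range from 1100 nM to 6500 nM.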

Compound 4, half-maximal inhibitory concentration: 2680 nM
The estimate for compound 4 lay 1.0-fold (0.01 log units) below the measured number, and the stated range covers the measured number.
By their numbers in this assay, from the lowest: compounds 1, 2, 4 and 3 (each within the scatter of the next).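

In this assay, chloro in place of (2-(dimethylamino)ethyl)amino on this aromatic carbon, opposite the ring nitrogen, gives a 1.2-fold lower number from compound 3 to compound 4 (0.07 log units; within the scatter) and so leaves the number within the scatter. This shows that the amino side chain is not needed at this place for a number of this size in this read-out. With chloro held at that place, phenyl on the ether chain gives a 1.0-fold higher number from compound 2 to compound 4 (0.01 log units; within the scatter) in place of propyl and a 1.2-fold higher number from compound 1 to compound 4 (0.08 log units; within the scatter) in place of isopropyl, so these ether groups cannot be told apart either. No measurement shown here bears on the result.

As far as these compounds go, whether another group at this place, such as a morpholine or a carboxylic acid, would move the number beyond the scatter stays open. So does the effect of a longer chain on the ether oxygen.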